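The source may report more compounds than this note shows. Statements on the series, on what has been measured and on what is new or still open speak of the compounds shown alone.

Three compounds share one core and differ only in the five-membered heteroaryl carried on a saturated chain carbon bound to an amine nitrogen in a ring. In an assay on isolated protein for displacement of a labelled ligand from Gonadotropin-releasing hormone receptor (Homo sapiens) (on this read-out higher numbers stand for weaker inhibition and lower numbers for stronger inhibition), compound 1 `CCc1nc(C)c(CN2CCN(c3cccc4[nH]c(-c5ccc(C(C)(C)C)cc5)nc34)CC2)s1` gives 20 nM, and compound 2 `Cc1nc(CN2CCN(c3cccc4[nH]c(-c5ccc(C(C)(C)C)cc5)nc34)CC2)c(C)s1` gives 21 nM; the two values sit within the scatter, as a 1.1-fold higher number from compound 1 to compound 2 (0.02 log units; within the scatter) shows. Compound 3 `CCc1cc(CN2CCN(c3cccc4[nH]c(-c5ccc(C(C)(C)C)cc5)nc34)CC2)nn1C` gives 43 nM in this assay, the highest number of the three, reached by a 2.2-fold higher number from compound 1 to compound 3 (0.33 log units; beyond the scatter) and a 2.0-fold higher number from compound 2 to compound 3 (0.31 log units; beyond the scatter).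

Compound 4 `CCCCn1cnc(CN2CCN(c3cccc4[nH]c(-c5ccc(C(C)(C)C)cc5)nc34)CC2)c1C` continues the same exchange at the same place: 1-butyl-5-methyl-1H-imidazol-4-yl in place of 5-ethyl-1-methyl-1H-pyrazol-3-yl on a saturated chain carbon bound to an amine nitrogen in a ring. The three measured steps all swap one such heteroaryl for another, and none moved this assay by more than a modest amount; the pyrazole in compound 3 gave the weakest number, while the two thiazoles sat close together. A return to a number nearer those of compounds 1 and 2 is therefore expected, though a change within the scatter remains plausible, so the estimated step is a 1.5-fold lower number from compound 3 to compound 4 (0.19 log units; within the scatter). Compound 4 is expected to give about 28 nM in this assay, between 12 nM and 70 nM.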

Compound 4, half-maximal inhibitory concentration: 46 nM
Compound 4: the middle estimate sits 1.6-fold (0.22 log units) below what was measured; low and high end bracket the measured number.
By their numbers in this assay, from the lowest: compounds 1 and 2 (each within the scatter of the next); then compounds 3 and 4 (each within the scatter of the next).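

In this assay, 1-butyl-5-methyl-1H-imidazol-4-yl and 5-ethyl-1-methyl-1H-pyrazol-3-yl cannot be told apart (a 1.1-fold higher number from compound 3 to compound 4 (0.03 log units; within the scatter)), so the larger group entering at this position leaves the number where compound 3 had it. Set against the two thiazoles, the same imidazole gives modest steps (a 2.2-fold higher number from compound 2 to compound 4 (0.34 log units; beyond the scatter); a 2.3-fold higher number from compound 1 to compound 4 (0.36 log units; beyond the scatter)). Among these four compounds, the two thiazoles therefore form the lower pair and the pyrazole and imidazole the higher pair, with no compound going against that split.

Nothing given here accounts for this split between the pairs. From the compounds shown here alone, it remains open whether a thiazole carrying a butyl chain would stay with compounds 1 and 2, and how a heteroaryl bearing an amine or a carboxylic acid would fare at this position.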